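The source may hold more compounds than are shown below. What is called first, only, known or untested is meant among the compounds shown, and "the series" means these compounds.

Values in a functional assay on SMOV2 cells (Homo sapiens) for antiproliferative activity, read by sulforhodamine B assay, with a stated time of 3 days (on this read-out lower numbers stand for stronger inhibition of growth and higher numbers for weaker inhibition of growth), so far
- compound 1 `CCc1cc(F)ccc1-c1nc(-c2ccc3[nH]c(=O)oc3c2)cs1` gives 13 nM
- compound 2 `Cc1cc(F)ccc1-c1nc(-c2ccc3[nH]c(=O)n(CCN(C)C)c3c2)cs1` gives 3 nM
- compound 3 `COCCOCc1cc(F)ccc1-c1nc(-c2ccc3[nH]c(=O)oc3c2)cs1` is not yet measured

Compound 1 holds the higher of the two numbers, and its gap to compound 2 lies beyond the scatter. The change from compound 1 to compound 3 is 2-methoxyethoxy in place of methyl on a saturated chain carbon bound to an aromatic carbon with 2-methoxyethoxy in place of methyl on a saturated chain carbon bound to an aromatic carbon. Going by the values given here, no measured step covers this change. A small step toward a higher number is expected in this assay and it may stay within the scatter. The estimated step is a 1.5-fold higher number from compound 1 to compound 3 (0.19 log units; within the scatter) on present data. The expected value for compound 3 is 20 nM with an estimated range of 7 nM to 60 nM on this read-out.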

Compound 3, concentration for 50% growth inhibition: 2 nM
Beside the measured number, compound 3's estimate is 10-fold (1.00 log units) above it; the measured number lies below the stated range.
By their numbers in this assay, from the lowest: compounds 3 and 2 (each within the scatter of the next); then compound 1.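

Replacing methyl with 2-methoxyethoxy on a saturated chain carbon bound to an aromatic carbon gives a 6.5-fold lower number from compound 1 to compound 3 (0.81 log units; beyond the scatter) in this assay. This position therefore accepts a much larger chain than the ethyl of compound 1 with no loss of growth inhibition, and the number falls instead. Nothing available bears on the reason for this gain.

From the compounds shown here alone, whether the gain depends on the chain's oxygens or on its length alone remains open. A longer all-carbon chain, a terminal amine or a carboxylic acid at this place would separate these readings.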